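The compounds below may be only part of what the source reports. "The series", "measured", "known", "first", "only" and "open" are said of these compounds alone.

Measured so far:
compound 1 `COc1ccc(-c2nc(SC)nc(NCCCCNc3ccnc4cc(Cl)ccc34)c2C#N)cc1`, in an ADME assay on CCRF-CEM cells (Homo sapiens) for inhibition, read by cell counting (a higher number here means a weaker inhibitor, a lower number a stronger inhibitor), compound 1 gives 2700 nM
compound 2 `COc1cc(-c2nc(SC)nc(NCCCCNc3ccnc4cc(Cl)ccc34)c2C#N)cc(OC)c1OC`, in this assay compound 2 gives 3600 nM

Compound 2 has the higher of the two numbers, but its separation from compound 1, a 1.3-fold higher number from compound 1 to compound 2 (0.12 log units; within the scatter), lies within the scatter. Compound 3 `CSc1nc(NCCCCNc2ccnc3cc(Cl)ccc23)c(C#N)c(-c2ccc(C)cc2)n1` carries 4-methylphenyl in place of 3,4,5-trimethoxyphenyl on an aromatic carbon. For the measured compounds named here, the only comparable step, the exchange of aryl groups from compound 1 to compound 2, barely moved the number. A similar swap here is therefore expected to give a 1.2-fold lower number from compound 2 to compound 3 (0.08 log units; within the scatter), no shift beyond the scatter. Compound 3 is thus estimated at 3000 nM in this assay, with a range of 1200 nM to 7500 nM.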

Compound 3, half-maximal inhibitory concentration: 4900 nM
Compound 3: the middle estimate sits 1.6-fold (0.21 log units) below what was measured; low and high end bracket the measured number.
By their numbers in this assay, from the lowest: compounds 1, 2 and 3 (each within the scatter of the next).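

In this assay, 4-methylphenyl in place of 3,4,5-trimethoxyphenyl gives a 1.4-fold higher number from compound 2 to compound 3 (0.13 log units; within the scatter), and methyl in place of methoxy gives a 1.8-fold higher number from compound 1 to compound 3 (0.26 log units; within the scatter). At this position, then, an aryl group with no hydrogen-bond acceptors and fewer heavy atoms stays within the scatter of those carrying methoxy groups. Nothing available explains this result.

As far as these compounds go, all three groups here are phenyl rings bearing methyl or methoxy, so it remains open whether a phenyl ring carrying an amine or a carboxylic acid would shift the number beyond the scatter.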